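From an Indole to an Acetylphenyl Group

The source may report more compounds than this note shows. Statements on the series, on what has been measured and on what is new or still open speak of the compounds shown alone.

In a functional assay on HCT-116 cells (Homo sapiens) for inhibition, read by CCK-8 assay, with a stated time of 48 h (a higher number here means a weaker inhibitor, a lower number a stronger inhibitor), compound 1 `COc1cc(-c2ccnc3cc(-c4ccc5cc[nH]c5c4)nn23)cc(OC)c1OC` gives 187 nM, while compound 2 `COc1cc(-c2ccnc3cc(-c4cn(C)c5ccccc45)nn23)cc(OC)c1OC` gives 762 nM, the higher of the two numbers. Compound 3 `COc1cc(-c2ccnc3cc(-c4ccc(C(C)=O)cc4)nn23)cc(OC)c1OC` carries a new group on the same aromatic carbon: 4-acetylphenyl in place of 1-methyl-1H-indol-3-yl (4-acetylphenyl in place of 1-methyl-1H-indol-3-yl on an aromatic carbon). Going by the values given here, the only measured step at this carbon, a 4.1-fold higher number from compound 1 to compound 2 (0.61 log units; beyond the scatter), is modest and links two indoles, so it gives no direct guide to a phenyl group. With the direction poorly defined, only a small change is expected, a 1.3-fold lower number from compound 2 to compound 3 (0.10 log units; within the scatter), probably within the scatter. Compound 3 is expected at 600 nM, with an estimated range of 150 nM to 2400 nM.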

Compound 3, half-maximal inhibitory concentration: 4390 nM
Compound 3: middle estimate off by 7.3-fold (0.86 log units), on the low side; measured number above the stated range.
By their numbers in this assay, from the lowest: compound 1; then compound 2; then compound 3.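

In this assay the move to 4-acetylphenyl gives a 5.8-fold higher number from compound 2 to compound 3 (0.76 log units; beyond the scatter) and, set against the other indole, a 23-fold higher number from compound 1 to compound 3 (1.37 log units; beyond the scatter) as the largest step yet at this aromatic carbon. Both indoles thus give lower numbers than 4-acetylphenyl, so this carbon responds to a swap from indole to a substituted phenyl, not only to a change between indoles. No evidence at hand accounts for this loss.

The compounds shown leave open whether the acetyl group or the absent five-membered aromatic ring matters more, and how a phenyl carrying an amine or a carboxylic acid would read.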